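The source may report more compounds than this note shows. Statements on the series, on what has been measured and on what is new or still open speak of the compounds shown alone.

Two sulfonyl-linked series are compared here in a functional assay on M21 cells (Homo sapiens) for cytotoxicity, read by sulforhodamine B assay, with a stated time of 48 h; on this read-out lower numbers stand for stronger inhibition and higher numbers for weaker inhibition. Compound 1 `CCNC(=O)Nc1ccc(S(=O)(=O)Oc2ccccc2CC)cc1` carries an ethyl group on its aryl ring, and in this assay compound 1 gives 2500 nM. Compound 2 `CCCc1ccccc1OS(=O)(=O)c1ccc(NC(=O)NCC)cc1` differs from compound 1 by methyl in place of hydrogen on a saturated chain carbon, two bonds along the chain from an aromatic carbon; in this assay compound 2 gives 800 nM. That single added carbon brought a 3.1-fold lower number from compound 1 to compound 2 (0.49 log units; beyond the scatter).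

Compound 3 `CCNC(=O)Nc1ccc(S(=O)(=O)Nc2ccccc2C)cc1` belongs to a second core; the difference between the two cores is not broken down here. In this assay compound 3 reaches only a limit of the assay, > 200000 nM, so no number is known for it (the limit of > 200000 nM in this assay, at which 1 of the 3 values shown sits).

Compound 4 `CCNC(=O)Nc1ccc(S(=O)(=O)Nc2ccccc2CC)cc1` has not yet been measured. It differs from compound 3 by methyl in place of hydrogen on a saturated chain carbon bound to an aromatic carbon. For the measured compounds named here, this is the same kind of change as the one from compound 1 to compound 2, but not the same: there the methyl entered on a saturated chain carbon two bonds along the chain from an aromatic carbon, here it enters on a saturated chain carbon bound to an aromatic carbon. Going by the values given here, the step seen from compound 1 to compound 2 is the only guide. For compound 4 a step of about a number no higher from compound 3 to compound 4 (the limit leaves the size open) is expected, resting on the gap a 3.1-fold lower number from compound 1 to compound 2 (0.49 log units; beyond the scatter) seen with the other core. Compound 3 offers only a limit (the limit of > 200000 nM in this assay, at which 1 of the 3 values shown sits), so the starting point is uncertain. Compound 4 is therefore estimated at 200000 nM, between 40000 nM and 1000000 nM, and it may again sit at the limit.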

Compound 4, half-maximal inhibitory concentration: 90000 nM
Compound 4: middle estimate off by 2.2-fold (0.35 log units), on the high side, and the stated range covers the measured number.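

In this assay, adding one carbon to the chain on the aromatic ring moves the number in the same direction on both cores: the same change on two cores in this assay, a 3.1-fold lower number (0.49 log units; beyond the scatter) from compound 1 to compound 2 and an at least 2.2-fold lower number (0.34 log units; beyond the scatter) from compound 3 to compound 4; the limit leaves it open whether they differ

Compound 3 gives > 200000 nM, which is a limit of the assay and not a number. The second core therefore shows an at least 2.2-fold lower number from compound 3 to compound 4 (0.34 log units; beyond the scatter), so the direction of the change carries over from one core to the other, but its size is not pinned down. For the compounds shown here, with only two pairs, and with the methyl entering at a different place on the chain in each, this supports no general rule and does not show that one added carbon is worth the same on both cores.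

The compounds shown leave open whether the trend continues with a longer chain, such as butyl, or with a branched group, such as isopropyl, on either core. They also leave open what a methoxy group or a chlorine atom in place of the alkyl chain would do, and whether compound 4, at 90000 nM, could approach compound 1, at 2500 nM, through any such change.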